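Extending the amine alkyl on a pyrimidine core

The compounds below may be only part of what the source reports. "The series", "measured", "known", "first", "only" and "open" are said of these compounds alone.

In a functional assay on LS174T cells (Homo sapiens) for antiproliferative activity (a lower number here means a stronger inhibitor, a higher number a weaker inhibitor), compound 1 `CNc1ccc(/C=C/c2c(F)cccc2F)cc1` gives 7.6 nM. Compound 2 `CCNc1ccc(/C=C/c2c(F)cccc2F)cc1` carries the change (methyl in place of hydrogen on a saturated chain carbon bound to a nitrogen on an aromatic ring), and in this assay it gives 200 nM; the step of a 26-fold higher number from compound 1 to compound 2 (1.42 log units; beyond the scatter) shows how much weaker the inhibitor became. Compound 3 `CNc1ncc(/C=C/c2c(F)cccc2F)cn1` has a different core; the difference between the two cores is not broken down here. In this assay compound 3 gives > 200 nM, which is a limit of the assay rather than a number (the limit of > 200 nM in this assay, at which 1 of the 3 values shown sits). Compound 4 `CCNc1ncc(/C=C/c2c(F)cccc2F)cn1` is compound 3 with the same change, (methyl in place of hydrogen on a saturated chain carbon bound to a nitrogen on an aromatic ring). The step from compound 3 to compound 4 is expected to be a step that the limit leaves unreadable from compound 3 to compound 4, an expectation resting on the step seen a 26-fold higher number from compound 1 to compound 2 (1.42 log units; beyond the scatter). Compound 4 is therefore estimated at 3000 nM, likely again beyond the limit.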

Compound 4, half-maximal inhibitory concentration: > 200 nM
Compound 4: no number, only a limit; the forecaster's own chance of this, stated with the estimate: 85%; the middle value lies beyond the limit too.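

Compound 3 and compound 4 both give a limit rather than a number, so the step between them cannot be read: the limit of > 200 nM in this assay, at which 2 of the 4 values shown sit. From the compounds shown here alone, whether methyl in place of hydrogen weakens compound 3 as much as it weakens compound 1 remains open.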